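Nitro position shift on the aryl group of compound 3

The compounds below may be only part of what the source reports. "The series", "measured", "known", "first", "only" and "open" are said of these compounds alone.

Compound 3 `COc1cc(C(=O)c2sc(-c3ccc([N+](=O)[O-])cc3)cc2N)cc(OC)c1OC` gives 100 nM in a functional assay on L1210 cells (Mus musculus) for antiproliferative activity; a lower number here means a stronger inhibitor, a higher number a weaker inhibitor. Compound 2 `COc1cc(C(=O)c2sc(-c3ccc(Br)cc3)cc2N)cc(OC)c1OC` gives 100 nM in this assay, so compound 3 stands level with it: no change at the digits printed from compound 2 to compound 3 (within the scatter). Compound 1 `COc1cc(C(=O)c2sc(-c3ccc(-c4ccccc4)cc3)cc2N)cc(OC)c1OC` gives only a limit, > 10000 nM, in this assay (the limit of > 10000 nM in this assay, at which 1 of the 3 values shown sits). The steps of an at least 100-fold lower number from compound 1 to compound 2 (2.00 log units; beyond the scatter) and an at least 100-fold lower number from compound 1 to compound 3 (2.00 log units; beyond the scatter) are both large, but each exchanges the group itself rather than its position. Compound 4 `COc1cc(C(=O)c2sc(-c3cccc([N+](=O)[O-])c3)cc2N)cc(OC)c1OC` differs from compound 3 in one place: 3-nitrophenyl in place of 4-nitrophenyl on an aromatic carbon. Among the compounds with values here, no measured step moves a group to another position on that ring, so none bears directly on this change; the expected step in this assay is a 2.0-fold higher number from compound 3 to compound 4 (0.30 log units; within the scatter), none beyond the scatter. Compound 4 is estimated at 200 nM in this assay, expected range 40 nM to 1500 nM.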

Compound 4, half-maximal inhibitory concentration: 11 nM
Compound 4: the middle estimate sits 18-fold (1.26 log units) above what was measured, outside the stated range (below it).
By their numbers in this assay, from the lowest: compound 4; then compounds 2 and 3 (each within the scatter of the next). At a limit, above all of these: compound 1.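

In this assay, the place of the nitro group on the aryl ring matters: 3-nitrophenyl in place of 4-nitrophenyl gives a 9.1-fold lower number from compound 3 to compound 4 (0.96 log units; beyond the scatter). Compounds 2 and 3 did not separate with 4-bromophenyl and 4-nitrophenyl, yet a 9.1-fold lower number from compound 2 to compound 4 (0.96 log units; beyond the scatter), so at this position the difference follows the arrangement on the aryl ring in these compounds, not the nitro group alone. Nothing measured here bears on why the shift has this effect.

Going by these compounds, whether bromo responds to the same shift remains open. Also open, on these data alone, is whether an amine or a carboxylic acid on this aryl ring would follow the nitro group.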